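The source may hold more compounds than are shown below. What is called first, only, known or untested is meant among the compounds shown, and "the series" means these compounds.

Compound 1 `Cc1c(Br)cc(C(=O)NC2CCNCC2)c(=O)n1Cc1ccc(F)cc1` was tested in an assay on HEK293 cells for inhibition of Monoacylglycerol lipase ABHD6 (Homo sapiens), read by scintillation counting, with stated times of 30 min and 5 min; on this read-out higher numbers stand for weaker inhibition and lower numbers for stronger inhibition. In this assay compound 1 gives > 10000 nM, which is a limit of the assay rather than a number. Two related compounds carrying a cycloheptyl amide were measured as well: compound 2 `Cc1ccc(C(=O)NC2CCCCCC2)c(OCc2ccc(F)cc2)n1` gives > 10000 nM, a limit of the assay. Compound 3 `Cc1nc(OCc2ccc(F)cc2)c(C(=O)NC2CCCCCC2)cc1Br` gives > 10000 nM, likewise a limit. The step that the two limits leave unreadable from compound 2 to compound 3 is therefore unreadable, because the limit of > 10000 nM in this assay, at which 3 of the 3 values shown sit, applies to every value shown. Compound 4 `Cc1c(Br)cc(C(=O)NC2CCCCCC2)c(=O)n1Cc1ccc(F)cc1` differs from compound 1 in one place: cycloheptyl in place of piperidin-4-yl on an amide-type nitrogen. For the measured compounds named here, no measured step reads on this change, and compounds 2 and 3 already bear the cycloheptyl amide at the limit. Compound 4 is therefore expected to remain at the limit, with a step that the limit leaves unreadable from compound 1 to compound 4 estimated near nothing, and an estimate of 15000 nM spanning 5000 nM to 50000 nM.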

Compound 4, half-maximal inhibitory concentration: > 10000 nM
Compound 4 gave a limit, no number; the forecaster's own chance of this, stated with the estimate: 80%; the middle value does not contradict the limit.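

Compound 1 and compound 4 both sit at a limit and give no number, so no step can be read between them: the limit of > 10000 nM in this assay, at which 4 of the 4 values shown sit.

The compounds shown leave open which change to the shared core or its amide, if any, would bring a measurable value in this assay.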